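The source may report more compounds than this note shows. Statements on the series, on what has been measured and on what is new or still open speak of the compounds shown alone.

Measured compounds:
Compound 1 `COc1ccc(-n2cc3nc(-c4ccccc4)nc(N)c3n2)cc1` gives 12% in an assay on CHO cells for displacement of a labelled ligand from adenosine receptor A1 (Homo sapiens), read by scintillation counting, with a stated time of 120 min, tested at 1 uM; a lower number here means less inhibition, a higher number more inhibition at the concentration tested (going by the name of the read-out).
Compound 2 `COc1ccc(-n2cc3nc(Cc4ccccc4)nc(N)c3n2)cc1` gives 40% in this assay.
Compound 3 `COc1ccc(-n2cc3nc(C)nc(NC(=O)c4ccco4)c3n2)cc1` gives 6% in this assay.

Compound 3 stands lowest of the three numbers; compound 1 lies within the scatter of it, while compound 2 lies beyond it. The step to compound 4 `COc1ccc(-n2cc3nc(C)nc(N)c3n2)cc1` is hydrogen in place of (furan-2-yl)carbonyl on a nitrogen on an aromatic ring. Among the compounds with values here, no measured step covers this change: the only one, a number 28 percentage points higher from compound 1 to compound 2 (beyond the scatter), concerns another part of the shared core. Compounds 1 and 2, which carry the free amino group, give low to modest inhibition, and compound 3 with the acylated nitrogen also sits low, so the data give no direction. Compound 4 is therefore expected to stay low, with the step of a number 9 percentage points higher from compound 3 to compound 4 (within the scatter) expected to fall within the scatter. The estimate for compound 4 is 15%, from 0% to 40%.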

Compound 4, a percentage reported as inhibition, at one concentration (the size of the read-out at that concentration, not a potency): 30%
The estimate for compound 4 lay 15 percentage points below the measured number, and the stated range covers the measured number.
By their numbers in this assay, from the lowest: compounds 3 and 1 (each within the scatter of the next); then compounds 4 and 2 (each within the scatter of the next).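

On the nitrogen on an aromatic ring, hydrogen in place of (furan-2-yl)carbonyl gives a number 24 percentage points higher from compound 3 to compound 4 (beyond the scatter) in this assay, so with methyl held on the aromatic carbon, the free amino form reads above the acylated one. At that aromatic carbon, methyl in place of phenyl gives a number 18 percentage points higher from compound 1 to compound 4 (beyond the scatter), whereas the change from benzyl gives a number 10 percentage points lower from compound 2 to compound 4 (within the scatter), so methyl and benzyl are not separated and phenyl alone reads low. Nothing at hand offers a reason for these steps. On these data alone, whether an acetyl or a methyl on that nitrogen would behave like (furan-2-yl)carbonyl remains open. So does the effect of a longer chain, such as 2-phenylethyl, on the aromatic carbon.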